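The source may report more compounds than this note shows. Statements on the series, on what has been measured and on what is new or still open speak of the compounds shown alone.

Compound 1, `COc1ccnc(Nc2cc3[nH]c(-c4cccc(C(F)(F)F)c4)nc3cn2)c1`, gives a limit in a physicochemical assay for solubility, using the shake flask method, in phosphate buffer, measured as kinetic solubility, with a stated time of 20 h, at pH 6.5 (a lower number here means a less soluble compound, a higher number a more soluble compound), of < 5000 nM.
Compound 2, `Fc1ccc(-c2nc3cnc(Nc4ccccn4)cc3[nH]2)cc1F`, gives a limit in this assay of < 5000 nM.
Compound 3, `Fc1ccc(Nc2cc3[nH]c(-c4ccc(F)c(F)c4)nc3cn2)nc1`, gives a limit in this assay of < 5000 nM.

Each of these three values is a limit of the assay rather than a number, so compound 1 stands at the limit of < 5000 nM in this assay, at which 3 of the 3 values shown sit, together with the other two, and nothing separates it from them. Among the compounds with values here, the one measured step that changes a single place, a step that the two limits leave unreadable from compound 2 to compound 3, is a fluoro in place of hydrogen on an aromatic carbon; both of its ends are limits, and its size cannot be read. Compound 4, `NC(=O)c1ccc(Nc2cc3[nH]c(-c4cccc(C(F)(F)F)c4)nc3cn2)nc1`, differs from compound 1 by 5-carbamoylpyridin-2-yl in place of 4-methoxypyridin-2-yl on a nitrogen on an aromatic ring. Within the data shown here, no measured step touches that position or that kind of exchange, so there is no measured step to lean on. With every measured value at the limit, the step from compound 1 to compound 4 in this assay is expected to be a step that the limit leaves unreadable from compound 1 to compound 4, a guess that cannot be checked against any measured step in either direction. Compound 4 is expected to give 3000 nM, with a range from 500 nM to 15000 nM, and this assay will most likely again report only a limit for it.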

Compound 4, solubility: < 5000 nM
Compound 4 ended at the assay's limit; the forecaster's own chance of this, stated with the estimate: 70%; the middle value does not contradict the limit.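

Compound 1 and compound 4 both stand at one limit, so no new step can be read from this pair: the limit of < 5000 nM in this assay, at which 4 of the 4 values shown sit.
The compounds shown leave open what number this assay would give for any of the four, and whether any exchange on the shared core moves that number.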